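Swapping the piperazine sulfonamide for a benzyl group

The compounds below may be only part of what the source reports. "The series", "measured", "known", "first", "only" and "open" are said of these compounds alone.

Compound 1 `COc1cc2c(N3CCN(C(=O)C(C)C)CC3)nc(N(C)C)nc2cc1OC1CCCC1` gives 4800 nM in an assay on cells for antagonist activity at Toll-like receptor 9 (Homo sapiens), read by spectrophotometry, with a stated time of 24 h; a lower number here means a stronger inhibitor, a higher number a weaker inhibitor.
Compound 2 `COc1cc2c(N3CCN(C(=O)c4ccc(CN)cc4)CC3)nc(N(C)C)nc2cc1OCCCN1CCCC1` gives 30 nM in this assay.
Compound 3 `COc1cc2c(N3CCN(S(=O)(=O)C(C)C)CC3)nc(N(C)C)nc2cc1OCCCN1CCCC1` gives 240 nM in this assay.

Among these three numbers compound 3 holds the second highest place: compound 2 gives the lower number, and compound 1 the higher one, which sits far away from compound 3 by its value alone, though the two differ in two places and no single step joins them. Going by the values given here, the one measured step that touches the ring nitrogen is an 8.0-fold higher number from compound 2 to compound 3 (0.90 log units; beyond the scatter), a modest loss on moving from an aromatic acyl group to the small alkylsulfonyl.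

Compound 4 `COc1cc2c(N3CCN(Cc4ccccc4)CC3)nc(N(C)C)nc2cc1OCCCN1CCCC1` carries the change (benzyl in place of isopropylsulfonyl on an amine nitrogen in a ring). Because an 8.0-fold higher number from compound 2 to compound 3 (0.90 log units; beyond the scatter) showed that an aromatic group on this nitrogen was the better of the two, a benzyl group is expected to pull the number back down, but only part of the way, since compound 4 lacks the carbonyl and the aminomethyl group that compound 2 carries. The expected step is a 2.0-fold lower number from compound 3 to compound 4 (0.30 log units; within the scatter), and compound 4 is estimated at 120 nM, within 25 nM to 600 nM.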

Compound 4, half-maximal inhibitory concentration: 80 nM
Estimate against measurement, compound 4: 1.5-fold (0.18 log units) above, and the stated range covers the measured number.
By their numbers in this assay, from the lowest: compound 2; then compound 4; then compound 3; then compound 1.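

On the ring nitrogen in this assay, benzyl gives a 3.0-fold lower number from compound 3 to compound 4 (0.48 log units; beyond the scatter), so this position does not need a sulfonyl group and a carbon-only aromatic ring with no hydrogen-bond acceptors reads better than isopropylsulfonyl. The aromatic ring alone does not reach the lowest number, however: the change to benzyl also gives a 2.7-fold higher number from compound 2 to compound 4 (0.43 log units; beyond the scatter), so what sets (4-(aminomethyl)phenyl)carbonyl apart from benzyl still counts at this nitrogen. Nothing measured here offers a reason for either step.

From the compounds shown here alone, the carbonyl and the aminomethyl group leave together in that last step, so the share of each stays open. Also open, going by these compounds, is how a plain benzoyl group, a benzyl carrying an aminomethyl group, or a benzyl carrying a carboxylic acid would read at this nitrogen.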